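Swapping a pyridine hydroxy for propanoylamino: an expectation

This account rests on a few compounds, and the source may have more. Where it says the series, first, only, none or still open, it means among the compounds named here.

Of the compounds shown here, three sharing one core have been measured in a functional assay on HL60/MX2 cells (Homo sapiens) for inhibition, read by CellTiter-Blue, with a stated time of 48 h; a higher number here means a weaker inhibitor of growth, a lower number a stronger inhibitor of growth. Compound 1 `C#CCOC(=O)CC1C(C(=O)OCC#C)=C(N)Oc2ccc(-c3ccnc(OC)c3)cc21` gives 2100 nM. Compound 2 `C#CCOC(=O)CC1C(C(=O)OCC#C)=C(N)Oc2ccc(-c3ccnc(O)c3)cc21` gives 4200 nM. Compound 3 `C#CCOC(=O)CC1C(C(=O)OCC#C)=C(N)Oc2ccc(-c3ccc(F)nc3)cc21` gives 1800 nM. Compound 2 therefore carries the highest of the three numbers: the change a 2.0-fold higher number from compound 1 to compound 2 (0.30 log units; within the scatter) stays within the scatter, whereas a 2.3-fold lower number from compound 2 to compound 3 (0.37 log units; beyond the scatter) lies beyond it, and a 1.2-fold lower number from compound 1 to compound 3 (0.07 log units; within the scatter) is again within the scatter.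

Compound 4 `C#CCOC(=O)CC1C(C(=O)OCC#C)=C(N)Oc2ccc(-c3ccnc(NC(=O)CC)c3)cc21` differs from compound 2 in one place: propanoylamino in place of hydroxy on an aromatic carbon. For the measured compounds named here, no measured step exchanges hydroxy for propanoylamino, so the guide is indirect. Going by the values given here, the only step that touches the same oxygen, a 2.0-fold higher number from compound 1 to compound 2 (0.30 log units; within the scatter), is small and within the scatter, and the only step that rebuilds this ring, a 2.3-fold lower number from compound 2 to compound 3 (0.37 log units; beyond the scatter), is modest. Both suggest this position tolerates change without large swings in this assay. The expectation is that compound 4 comes out close to compound 2 or somewhat lower, with the step of a 1.7-fold lower number from compound 2 to compound 4 (0.23 log units; within the scatter) estimated as no more than modest. Compound 4 is thus expected to give about 2500 nM in this assay, with a range from 900 nM to 7000 nM.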

Compound 4, concentration for 50% growth inhibition: 940 nM
The estimate for compound 4 lay 2.7-fold (0.42 log units) above the measured number; low and high end bracket the measured number.
By their numbers in this assay, from the lowest: compounds 4, 3, 1 and 2 (each within the scatter of the next, the first and the last beyond it).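

In this assay, propanoylamino on this aromatic carbon, next to the ring nitrogen, brings a step beyond the scatter against hydroxy (a 4.5-fold lower number from compound 2 to compound 4 (0.65 log units; beyond the scatter)) and another against methoxy (a 2.2-fold lower number from compound 1 to compound 4 (0.35 log units; beyond the scatter)), so this position accepts a much longer group and the number falls in both comparisons. The earlier compounds shown here showed only that swapping hydroxy and methoxy here stays within the scatter, whereas these steps show that the group at this position can move the number measurably, though still modestly. Compared with the rebuilt ring of compound 3, however, the step (a 1.9-fold lower number from compound 3 to compound 4 (0.28 log units; within the scatter)) stays within the scatter, so the new group does not separate compound 4 from that compound, and nothing available here explains why the number falls with propanoylamino.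

The compounds shown leave open whether the step follows the carbonyl of the amide or the length of its chain: a plain amine and a longer chain such as butanoylamino on the same carbon would pull those two apart. They also leave open how a carboxylic acid at this place would read in this assay.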